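Compound 3 to compound 4: ethoxy out, trifluoromethyl in

A few compounds are considered here, and "the series" means these few. Any claim that something is new, unique, unknown or untested is made for them only; others in the source may bear on it.

For the measured compounds named here, in a functional assay on MCF7 cells (Homo sapiens) for inhibition, read by sulforhodamine B assay (on this read-out lower numbers stand for stronger inhibition and higher numbers for weaker inhibition), compound 3 (`CCOc1ccc(NC2=CC(=O)c3nc4n(c3C2=O)[C@H]2OC[C@@H](O)[C@H]2OC4)cc1`) gives 1430 nM, the lowest number so far. Compound 1 (`O=C1C=C(Nc2cccc(F)c2)C(=O)c2c1nc1n2[C@H]2OC[C@@H](O)[C@H]2OC1`) gives 5500 nM. Compound 2 (`O=C1C=C(NC2CCCC2)C(=O)c2c1nc1n2[C@H]2OC[C@@H](O)[C@H]2OC1`) reads > 16000 nM, which is a limit of the assay and not a number.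

Compound 4 (`O=C1C=C(Nc2ccc(C(F)(F)F)cc2)C(=O)c2c1nc1n2[C@H]2OC[C@@H](O)[C@H]2OC1`) has trifluoromethyl in place of ethoxy on an aromatic carbon, para to a large group: trifluoromethyl in place of ethoxy on an aromatic carbon. Cut one bond further out, this reads 4-ethoxyphenyl to 4-(trifluoromethyl)phenyl.

Going by the values given here, no measured step changes this group alone. The nearest evidence comes from changes on the amine nitrogen. The step with 4-ethoxyphenyl in place of 3-fluorophenyl is a 3.8-fold lower number from compound 1 to compound 3 (0.59 log units; beyond the scatter), and the step with 4-ethoxyphenyl in place of cyclopentyl is an at least 11-fold lower number from compound 2 to compound 3 (1.04 log units; beyond the scatter). The step with cyclopentyl in place of 3-fluorophenyl is an at least 2.9-fold higher number from compound 1 to compound 2 (0.46 log units; beyond the scatter). Compound 4 keeps a phenyl on that nitrogen, so the step to compound 1 is the closer guide, and the large step to compound 2 is given less weight. Compound 4 loses the ethoxy, and compound 1, the other measured phenyl without it, lies higher by a 3.8-fold lower number from compound 1 to compound 3 (0.59 log units; beyond the scatter). A modest step toward a higher number is therefore expected.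

The expected change is a 2.4-fold higher number from compound 3 to compound 4 (0.39 log units; beyond the scatter).

For compound 4 the estimate is 3500 nM, with an expected range of 1300 nM to 10000 nM.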

Compound 4, half-maximal inhibitory concentration: > 4000 nM
Compound 4: no number, only a limit (the forecaster's own chance of this, stated with the estimate: 8%); at least 1.1-fold (0.05 log units) between middle value and limit.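

In this assay, for the compounds shown here, this is the first measured change made at the outer end of the aryl group while the phenyl on the amine nitrogen stays in place: trifluoromethyl in place of ethoxy on an aromatic carbon, para to a large group, gives an at least 2.7-fold higher number from compound 3 to compound 4 (0.44 log units; beyond the scatter). The earlier steps shown here all replaced the whole group on that nitrogen, so they could not separate the ethoxy from the rest of the 4-ethoxyphenyl; this step shows that the low number of compound 3 does not survive this one exchange, and compound 3 remains the lowest of the four compounds. The reading for compound 4 is a limit and not a number, so the step has a lower bound but no measured size: the limit of > 4000 nM in this assay, at which 1 of the 4 values shown sits.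

The steps to compound 4 from compound 1 and from compound 2 cannot be read, which leaves open how 4-(trifluoromethyl)phenyl ranks against 3-fluorophenyl and cyclopentyl. Also open, as far as these compounds go, is how much of the result belongs to ethoxy itself, a question that methoxy, a longer alkoxy chain or an amine on the same aromatic carbon would address.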